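Trimethoxyphenyl in place of methoxyphenyl on the shared core

The compounds below may be only part of what the source reports. "The series", "measured", "known", "first", "only" and "open" are said of these compounds alone.

Of the compounds shown here, three have been measured in a functional assay on SK-OV-3 cells (Homo sapiens) for inhibition; a higher number here means a weaker inhibitor of growth, a lower number a stronger inhibitor of growth. Compound 1 `COc1cc(/C=C/C(=O)c2cccc(-n3cc(-c4ccc(Cl)cc4)[nH]c3=O)c2)ccc1O` gives 3190 nM. Compound 2 `COc1ccc(-c2cn(-c3cccc(C(=O)/C=C/c4cc(OC)c(OC)c(OC)c4)c3)c(=O)[nH]2)cc1` gives 4600 nM. Compound 3 `COc1ccc(-c2cn(-c3cccc(C(=O)/C=C/c4ccc(O)c(OC)c4)c3)c(=O)[nH]2)cc1` gives 4770 nM. Among these numbers compound 2 holds the second highest; it sits closest to compound 3, and the gap between them is within the scatter, while the gap to compound 1 is also within the scatter, so the three compounds cannot be told apart on these data.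

Compound 4 `COc1cc(/C=C/C(=O)c2cccc(-n3cc(-c4cc(OC)c(OC)c(OC)c4)[nH]c3=O)c2)cc(OC)c1OC` is not yet measured. It differs from compound 2 in one place: 3,4,5-trimethoxyphenyl in place of 4-methoxyphenyl on an aromatic carbon.

Among the compounds with values here, one measured step touches the same aromatic carbon of the shared core, the change from compound 1 to compound 3, with methoxy in place of chloro; that gave a 1.5-fold higher number from compound 1 to compound 3 (0.17 log units; within the scatter). The other measured step, from compound 2 to compound 3, changed a different part of the molecule and gave a 1.0-fold higher number from compound 2 to compound 3 (0.02 log units; within the scatter). Both steps stayed within the scatter, so a change on this aromatic carbon, or an added pair of methoxy groups elsewhere, has so far not moved the number in a way that can be trusted.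

For compound 4 no step beyond the scatter is therefore expected; the expected step is a 1.0-fold lower number from compound 2 to compound 4 (0.01 log units; within the scatter). Compound 4 is estimated to give 4500 nM, with a likely range from 1800 nM to 11000 nM.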

Compound 4, concentration for 50% growth inhibition: 5120 nM
Compound 4: middle estimate off by 1.1-fold (0.06 log units), on the low side; low and high end bracket the measured number.
By their numbers in this assay, from the lowest: compounds 1, 2, 3 and 4 (each within the scatter of the next).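

In this assay, the aromatic carbon of the five-membered ring now carries a larger group: 3,4,5-trimethoxyphenyl, with 12 heavy atoms and 3 hydrogen-bond acceptors, stands in place of 4-methoxyphenyl, with 8 heavy atoms and 1 acceptor (a 1.1-fold higher number from compound 2 to compound 4 (0.05 log units; within the scatter)). Within the data shown here, the earlier step at this carbon exchanged only chloro for methoxy on the phenyl ring, so this pair is the first to show that a phenyl ring bearing two extra methoxy groups here still leaves the number within the scatter. No measurement among those available explains this outcome or says what the added groups do.

Going by these compounds, all four compounds stand within the scatter of their neighbours in the order of their numbers, so it remains open whether any group on this aromatic carbon can shift the growth inhibition measurably. A phenyl ring carrying an amine or a carboxylic acid, or a longer chain in place of the ring, would show whether this position responds to groups of a different kind from the chloro and methoxy phenyl rings shown here.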